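A few compounds are considered here, and "the series" means these few. Any claim that something is new, unique, unknown or untested is made for them only; others in the source may bear on it.

Measured compounds:
compound 1, `CC1=NN(C(=O)c2ccc(C)cc2)C(c2cc(Br)cc(Br)c2O)C1`, in a functional assay on PC-3 cells (Homo sapiens) for cytotoxicity, read by MTT assay, with a stated time of 48 h (a higher number here means a weaker inhibitor, a lower number a stronger inhibitor), compound 1 gives 41200 nM
compound 2, `O=C(CCl)N1N=C(c2cc3ccccc3oc2=O)CC1c1ccccc1`, in this assay compound 2 gives 2980 nM

Compound 2 holds the lower of the two numbers; the gap to compound 1 lies beyond the usual scatter, so compound 2 is the stronger inhibitor of the two. Among the measured compounds shown here, the two compounds share no single point of difference, and no step between them is drawn.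

Compound 3, `CC(C)CNCC(=O)N1N=C(c2cc3ccccc3oc2=O)CC1c1ccccc1`, is the next entry, not yet measured. It differs from compound 2 in one place: isobutylamino in place of chloro on a saturated chain carbon bound to a carbonyl carbon. For the measured compounds named here, no measured pair in this set reports the effect of such an exchange, so the expectation rests on the position of compound 2 alone. The step from compound 2 to compound 3 is expected to go toward a higher number, beyond the scatter, a 3.0-fold higher number from compound 2 to compound 3 (0.48 log units; beyond the scatter). Compound 3 is therefore estimated at 9000 nM, with a range of 2500 nM to 35000 nM.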

Compound 3, half-maximal inhibitory concentration: 1920 nM
The estimate for compound 3 lay 4.7-fold (0.67 log units) above the measured number; the whole stated range lies above it.
By their numbers in this assay, from the lowest: compounds 3 and 2 (each within the scatter of the next); then compound 1.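

In this assay, isobutylamino in place of chloro on a saturated chain carbon bound to a carbonyl carbon gives a 1.6-fold lower number from compound 2 to compound 3 (0.19 log units; within the scatter), a step within the scatter, so the two compounds cannot be separated at this position. In this pair, chloro is therefore not needed for a number at this level: the larger isobutylamino, which brings a hydrogen-bond donor and acceptor, gives a matching reading. Nothing measured here accounts for this result.

From the compounds shown here alone, whether a morpholine, a primary amine, a carboxylic acid or a longer chain at this place would hold the number at this level remains open. This single step defines no trend for the position, and compound 1 cannot be compared with either compound in one place.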